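A few compounds are considered here, and "the series" means these few. Any claim that something is new, unique, unknown or untested is made for them only; others in the source may bear on it.

In a functional assay on CCRF-CEM cells (Homo sapiens) for cytotoxicity, read by MTT assay, with a stated time of 72 h (a lower number here means a stronger inhibitor of growth, a higher number a weaker inhibitor of growth), compound 2 `N#C[Se]c1ccc(NC(=O)Oc2ccc(F)cc2)cc1` gives 12600 nM, numerically the lowest of the three numbers shown, though both other compounds lie within the scatter of it. Compound 1 `COc1ccc(OC(=O)Nc2ccc([Se]C#N)cc2)cc1` gives 13000 nM, and compound 3 `CCCCOC(=O)Nc1ccc([Se][Se]c2ccc(NC(=O)OCCCC)cc2)cc1` gives 16700 nM. Compound 4 `Cc1ccc(OC(=O)Nc2ccc([Se]C#N)cc2)cc1` differs from compound 2 by methyl in place of fluoro on an aromatic carbon. For the measured compounds named here, only one measured step bears on this change, a 1.0-fold lower number from compound 1 to compound 2 (0.01 log units; within the scatter), which swapped the group at the same place and stayed within the scatter. A similarly small step is therefore expected here, with no settled direction, so the expected step is a 1.1-fold lower number from compound 2 to compound 4 (0.02 log units; within the scatter). Compound 4 is accordingly estimated at 12000 nM, with a range from 6000 nM to 25000 nM.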

Compound 4, concentration for 50% growth inhibition: 17400 nM
Compound 4: middle estimate off by 1.5-fold (0.16 log units), on the low side, and the stated range covers the measured number.
By their numbers in this assay, from the lowest: compounds 2, 1, 3 and 4 (each within the scatter of the next).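

In this assay, the place para to a large group on the aromatic ring now carries three different groups: methoxy, fluoro and methyl. Methyl in place of fluoro gives a 1.4-fold higher number from compound 2 to compound 4 (0.14 log units; within the scatter), and methyl in place of methoxy gives a 1.3-fold higher number from compound 1 to compound 4 (0.13 log units; within the scatter). Both steps lie within the scatter, as did the earlier swap of fluoro for methoxy, so none of these three groups can be told apart from another at this place.

On these data alone, whether an amine, a carboxylic acid or a longer chain here would give a step beyond the scatter stays open. No measurement shown offers a reason for these numbers.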